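Imine substituent swap across two aminopyrimidine cores

This account rests on a few compounds, and the source may have more. Where it says the series, first, only, none or still open, it means among the compounds named here.

Compound 1 `CCOC(=O)/C=N/c1cnc(Nc2ccc(S(N)(=O)=O)cc2)nc1NC1CCCC1` and compound 2 `NS(=O)(=O)c1ccc(Nc2ncc(/N=C/c3ccccc3)c(NC3CCCC3)n2)cc1` share one core; compound 3 `CCOC(=O)/C=N/c1cnc(Nc2ccc(N3CCN(C)CC3)cc2)nc1NC(C)C` and compound 4 `CC(C)Nc1nc(Nc2ccc(N3CCN(C)CC3)cc2)ncc1/N=C/c1ccccc1` share another. The difference between the two cores is not broken down here.

In a functional assay on HeLa cells (Homo sapiens) for antiproliferative activity, read by MTT assay (a higher number here means a weaker inhibitor, a lower number a stronger inhibitor), compound 1 gives 20700 nM. In this assay compound 2 gives 15600 nM. The change from compound 1 to compound 2 is phenyl in place of ethoxycarbonyl on a carbon with a double bond to nitrogen and it made a 1.3-fold lower number from compound 1 to compound 2 (0.12 log units; within the scatter). In this assay compound 3 gives 11500 nM, a number within the scatter of both compound 1 and compound 2.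

The change from compound 3 to compound 4 is phenyl in place of ethoxycarbonyl on a carbon with a double bond to nitrogen, the same change at the same place as from compound 1 to compound 2; it occurs twice among the compounds shown. Within the data shown here, the step expected in this assay is a 1.3-fold lower number from compound 3 to compound 4 (0.11 log units; within the scatter), because the one measured pair gave a 1.3-fold lower number from compound 1 to compound 2 (0.12 log units; within the scatter) and nothing else bears on it. Compound 4 is estimated at 9000 nM in this assay, with an expected range from 4500 nM to 18000 nM.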

Compound 4, half-maximal inhibitory concentration: > 100000 nM
Compound 4: only a limit was reported; the forecaster's own chance of this, stated with the estimate: 5%; at least 11-fold (1.04 log units) between middle value and limit.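

In this assay, phenyl in place of ethoxycarbonyl on a carbon with a double bond to nitrogen gave an at least 8.6-fold higher number from compound 3 to compound 4 (0.93 log units; beyond the scatter), so this change does not carry from one core to the other as a constant step: the same change on two cores in this assay, a 1.3-fold lower number (0.12 log units; within the scatter) from compound 1 to compound 2 and an at least 8.6-fold higher number (0.93 log units; beyond the scatter) from compound 3 to compound 4, at least 11-fold (1.06 log units) apart, beyond the scatter of two such steps

The value of compound 4, > 100000 nM, is a limit of the assay and not a number: the limit of > 100000 nM in this assay, at which 1 of the 4 values shown sits.

These two pairs do not show which part of the difference between the cores goes with the gap, and with one pair on each core they give no cause for it.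

Still open, from the compounds shown here alone, is whether the outcome on the core of compound 3 depends on its ring substituent, its isopropylamino group or both, as the two cores differ at both places together. Also open, going by these compounds, is how a carboxylic acid or an amide on the same carbon would compare with ethoxycarbonyl and phenyl on each core.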